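The source may hold more compounds than are shown below. What is called first, only, known or untested is meant among the compounds shown, and "the series" means these compounds.

Compound 2 `Cc1ccccc1-c1cc2ccccc2[nH]1` and compound 1 `Clc1ccccc1-c1cc2ccccc2[nH]1` share a core. For the measured compounds named here, in an assay on isolated protein for inhibition of Aromatase (Homo sapiens), read by fluorescence, using NADPH, with a stated time of 30 min, tested at 50 uM (on this read-out higher numbers stand for more inhibition at the one concentration tested (going by the name of the read-out) and lower numbers for less inhibition), compound 2 gives 27.1% and compound 1 gives 21.5%, with the only measured step being a number 5.6 percentage points higher from compound 1 to compound 2 (within the scatter), so neither compound can be set above the other on these numbers. Compound 3 `Cc1ccccc1-c1cc2cc([N+](=O)[O-])ccc2[nH]1` differs from compound 2 by nitro in place of hydrogen on an aromatic carbon. Going by the values given here, no measured step exchanges hydrogen for nitro on the shared core, so the single known step does not bear on this change, and no step beyond the scatter is expected. Compound 3 is therefore estimated at 27%, between 10% and 50%, an expected step of a number 0.1 percentage points lower from compound 2 to compound 3 (within the scatter).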

Compound 3, a percentage reported as inhibition, at one concentration (the size of the read-out at that concentration, not a potency): 71.5%
Estimate against measurement, compound 3: 44.5 percentage points below, outside the stated range (above it).
By their numbers in this assay, from the lowest: compounds 1 and 2 (each within the scatter of the next); then compound 3.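

In this assay, nitro in place of hydrogen on this aromatic carbon, meta to a fused ring and para to a fused ring, gives a number 44.4 percentage points higher from compound 2 to compound 3 (beyond the scatter), a large step. The only earlier step, chloro to methyl at a different place, stayed within the scatter, so this position is the one place shown where a change moves the number beyond it. Nothing available explains the size of this step.

As far as these compounds go, whether an amine, a carboxylic acid or a nitrile at this position would give a similar number stays open. Also open, from the compounds shown here alone, is whether nitro on the other carbons of this ring would give a comparable step.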